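This account rests on a few compounds, and the source may have more. Where it says the series, first, only, none or still open, it means among the compounds named here.

Of the compounds shown here, two have numbers so far. Compound 1 `O=C(Nc1cccc(-c2oc3cc(-c4ccc(F)cc4)ccc3c(=O)c2O)c1)c1ccc(Cl)cc1` in a functional assay on A549 cells (Homo sapiens) for antiproliferative activity, read by CCK-8 assay, with a stated time of 72 h (a lower number here means a stronger inhibitor, a higher number a weaker inhibitor), gives 10800 nM. Compound 2 `Cc1cc(C)cc(C(=O)Nc2cccc(-c3oc4cc(-c5ccc(F)cc5)ccc4c(=O)c3O)c2)c1` in this assay gives 3740 nM, and the step is a 2.9-fold lower number from compound 1 to compound 2 (0.46 log units; beyond the scatter). Within the data shown here, compound 2 therefore holds the lowest of the two numbers, with compound 1 the only neighbour and clearly separated from it.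

Compound 3 `O=C(Nc1cccc(-c2oc3cc(-c4ccc(F)cc4)ccc3c(=O)c2O)c1)c1cc(F)cc(F)c1` is the next case: 3,5-difluorophenyl in place of 3,5-dimethylphenyl on a carbonyl carbon. Among the measured compounds shown here, the only measured step that bears on this position is the one from compound 1 to compound 2, a 2.9-fold lower number from compound 1 to compound 2 (0.46 log units; beyond the scatter), where a ring carrying a halogen was exchanged for the 3,5-dimethylphenyl ring. Compound 3 returns a halogen-bearing ring at this carbonyl carbon, though with two fluorines in the 3,5-pattern rather than one chlorine, so the earlier step is only a partial guide. The expectation is a step back toward the number of compound 1, of modest size, a 1.6-fold higher number from compound 2 to compound 3 (0.21 log units; within the scatter). Compound 3 in this assay is thus estimated at 6000 nM, with a range from 2500 nM to 15000 nM.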

Compound 3, half-maximal inhibitory concentration: 7620 nM
The estimate for compound 3 lay 1.3-fold (0.10 log units) below the measured number; measured number inside the range.
By their numbers in this assay, from the lowest: compound 2; then compounds 3 and 1 (each within the scatter of the next).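

The 3,5-pattern on its own does not carry the lower number: with 3,5-difluorophenyl on the carbonyl carbon in place of 3,5-dimethylphenyl, this assay shows a 2.0-fold higher number from compound 2 to compound 3 (0.31 log units; beyond the scatter). A second halogen-bearing ring now sits alongside the 4-chlorophenyl ring, and exchanging one for the other gives a 1.4-fold lower number from compound 1 to compound 3 (0.15 log units; within the scatter), so the two halogen-bearing rings are not separated here, and among these three compounds only the 3,5-dimethylphenyl ring of compound 2 stands apart, as the strongest. No measurement available here bears on why the methyl and halogen groups on this ring part in this way.

Open, as far as these compounds go, is whether the lower number belongs to the methyl groups themselves or to any ring without halogen, a question that an unsubstituted phenyl, 3-methylphenyl, 3,5-dimethoxyphenyl or a saturated cyclohexyl at the same carbonyl carbon would address. Also open, from the compounds shown here alone, is whether a ring carrying an amine or a carboxylic acid would follow either of these two levels, and whether the order among the three compounds holds on any other cell line or with the amide replaced.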